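Capping a phenol as a methyl ether on a shared core

A few compounds are considered here, and "the series" means these few. Any claim that something is new, unique, unknown or untested is made for them only; others in the source may bear on it.

Measured so far:
- Compound 1, `O=C(Nc1cccc(-n2cc(-c3ccncc3)c(-c3cc(O)cc(Cl)c3)n2)c1)Nc1ccc(Cl)c(C(F)(F)F)c1`: 95% in a functional assay on SF-268 cells (Homo sapiens) for inhibition, read by sulforhodamine B assay, with a stated time of 48 h, tested at 0.01 uM; on this read-out higher numbers stand for a weaker effect at the one concentration tested and lower numbers for a stronger effect
- Compound 2, `O=C(Nc1cccc(-n2cc(-c3ccncc3)c(-c3cc(O)cc(Cl)c3)n2)c1)Nc1ccc(Cl)c(Cl)c1`: 94% in this assay

Compound 1 and compound 2 share one core and differ only in a single group on an outer aromatic ring. In this assay compound 1 gives 95%, the higher of the two numbers, while the step of a number 1 percentage points lower from compound 1 to compound 2 (within the scatter) is too small to mean anything, so the two compounds look alike on this read-out.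

Compound 3, `COc1cc(Cl)cc(-c2nn(-c3cccc(NC(=O)Nc4ccc(Cl)c(C(F)(F)F)c4)c3)cc2-c2ccncc2)c1`, has not yet been measured in this assay. It departs from compound 1 in one place: methyl in place of hydrogen on an oxygen on an aromatic ring. Among the measured compounds shown here, no measured step touches that hydroxy group, so the only guidance is the change from compound 1 to compound 2, which left the read-out essentially untouched. On that basis compound 3 is expected to behave much as compound 1 does, with no step beyond the scatter. The expected step is a number 1 percentage points lower from compound 1 to compound 3 (within the scatter). The estimate for compound 3 in this assay is 94%, with a range from 84% to 100%.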

Compound 3, a percentage reported as activity, at one concentration (the size of the read-out at that concentration, not a potency): 95%
Compound 3: middle estimate off by 1 percentage points, on the low side; the measured number falls inside the stated range.
By their numbers in this assay, from the lowest: compounds 2, 1 and 3 (each within the scatter of the next).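

Replacing hydroxy with methoxy on the 3-chloro-5-hydroxyphenyl ring gives no change at the digits printed from compound 1 to compound 3 (within the scatter) in this assay, so at the one concentration tested, methyl can take the place of the hydrogen on that oxygen without any visible shift in the read-out. Among the compounds shown here, the earlier pair spoke only to the chloro and trifluoromethyl groups on a different outer ring, so this is the first reading at the hydroxy position itself, and it suggests that the free hydroxy group is not needed to keep the number where compound 1 has it. No evidence is available to explain why the number holds steady.

Going by these compounds, a single concentration does not give a potency, so it remains open whether compound 1 and compound 3 would separate at other concentrations. On these data alone, it also remains open whether a longer chain on the oxygen, such as ethyl or propyl, or an amine or a carboxylic acid in place of the hydroxy group, would move the read-out beyond the scatter.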